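Propyl in place of an aryl group on the shared core

The source may hold more compounds than are shown below. What is called first, only, known or untested is meant among the compounds shown, and "the series" means these compounds.

Three compounds were measured in a functional assay on MCF7 cells (Homo sapiens) for inhibition, read by MTT assay, with a stated time of 48 h (a higher number here means a weaker inhibitor, a lower number a stronger inhibitor), with these results
Compound 1 `Oc1ccc(C(c2c[nH]c3ccc(Br)cc23)c2c[nH]c3ccc(Br)cc23)cc1` gives 3500 nM
Compound 2 `COc1cccc(C(c2c[nH]c3ccc(Br)cc23)c2c[nH]c3ccc(Br)cc23)c1OC` gives 89000 nM
Compound 3 `CN(C)c1ccc(C(c2c[nH]c3ccc(Br)cc23)c2c[nH]c3ccc(Br)cc23)cc1` gives 24900 nM

Compound 3 holds the middle of the three numbers, with a 3.6-fold lower number from compound 2 to compound 3 (0.55 log units; beyond the scatter) on one side and a 7.1-fold higher number from compound 1 to compound 3 (0.85 log units; beyond the scatter) on the other. Compound 4 `CCCC(c1c[nH]c2ccc(Br)cc12)c1c[nH]c2ccc(Br)cc12` has not yet been measured. It carries propyl in place of 4-(dimethylamino)phenyl on a saturated chain carbon bound to two aromatic carbons, and the change counts as propyl in place of 4-(dimethylamino)phenyl on a saturated chain carbon bound to two aromatic carbons in full. The three measured steps each exchange one substituted phenyl group for another. The largest is a 25-fold higher number from compound 1 to compound 2 (1.41 log units; beyond the scatter) and the other two are modest. None of them replaces the ring with a chain, and they give no direction for such a change. The spread among the three compounds does warn that this position can move the number considerably. No step beyond the scatter is therefore expected, and the estimate is a 1.1-fold lower number from compound 3 to compound 4 (0.05 log units; within the scatter) with a wide margin either way. For compound 4 the expected value is 22000 nM with an estimated range from 6000 nM to 80000 nM in this assay.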

Compound 4, half-maximal inhibitory concentration: 3600 nM
Compound 4: middle estimate off by 6.1-fold (0.79 log units), on the high side, and the stated range ends above it.
By their numbers in this assay, from the lowest: compounds 1 and 4 (each within the scatter of the next); then compound 3; then compound 2.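

Propyl is the first chain at this place, on a saturated chain carbon bound to two aromatic carbons, and it shows that an aromatic ring is not needed there for a number as low as that of compound 1 in this assay (a 1.0-fold higher number from compound 1 to compound 4 (0.01 log units; within the scatter)). Whether the change helps depends on the ring it replaces: the number falls against 4-(dimethylamino)phenyl (a 6.9-fold lower number from compound 3 to compound 4 (0.84 log units; beyond the scatter)) and against 2,3-dimethoxyphenyl (a 25-fold lower number from compound 2 to compound 4 (1.39 log units; beyond the scatter)), whereas compound 1 goes against any general gain from propyl. Nothing available explains this difference between the rings.

As far as these compounds go, whether an ethyl or butyl chain, or a cyclohexyl ring, would keep the number at this level remains open. So does the outcome of a propyl chain ending in a hydroxy group or an amine.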